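Adding a Methyl to a Free Hydroxy Group

A few compounds are considered here, and "the series" means these few. Any claim that something is new, unique, unknown or untested is made for them only; others in the source may bear on it.

Measured in a functional assay on MCF7 cells (Homo sapiens) for cytotoxicity, read by sulforhodamine B assay, with a stated time of 48 h (on this read-out higher numbers stand for weaker inhibition of growth and lower numbers for stronger inhibition of growth), so far
Compound 1 `COc1cc(C(=O)c2ccc(OC)c(O)c2OC)cc(OC)c1O` gives 1010 nM
Compound 2 `COc1cc(C(=O)c2ccc3c(c2)oc(=O)n3S(C)(=O)=O)cc(OC)c1OC` gives 4430 nM

Compound 1 has the lower of these two numbers, so it is the stronger growth inhibitor of the pair. Compound 3 `COc1ccc(C(=O)c2cc(OC)c(OC)c(OC)c2)c(OC)c1O` has not yet been measured in this assay and differs from compound 1 in one place. The change is methyl in place of hydrogen on an oxygen on an aromatic ring in the form of methyl in place of hydrogen on an oxygen on an aromatic ring, or hydroxy to methoxy. For the measured compounds named here, no measured pair shows this change alone, and compound 2 differs from compound 1 too widely to set its size. The expectation is therefore a judgement, with wide uncertainty. A moderate fall in the number is expected, a 2.9-fold lower number from compound 1 to compound 3 (0.46 log units; beyond the scatter) by this estimate. For compound 3 the estimated value is 350 nM with an expected range of 60 nM to 2000 nM in repeated measurements.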

Compound 3, concentration for 50% growth inhibition: 26.4 nM
The estimate for compound 3 lay 13-fold (1.12 log units) above the measured number, outside the stated range (below it).
By their numbers in this assay, from the lowest: compound 3; then compound 1; then compound 2.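

In this assay the exchange of hydrogen for methyl on this oxygen, hydroxy to methoxy, brings a 38-fold lower number from compound 1 to compound 3 (1.58 log units; beyond the scatter) and so shows that this single place on the core of compound 1 matters greatly for growth inhibition. Compound 3 still carries its other free hydroxy group, so this large step does not require removing every hydroxy group from the molecule. Nothing at hand gives a reason for so large a step from one added methyl. From the compounds shown here alone, how an ethoxy group, a longer chain on this oxygen or an amine in place of the hydroxy group would compare remains open. Also open, going by these compounds, is whether adding a methyl to the remaining hydroxy group of compound 3 would move the number in the same direction.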